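Chain Extension on the Butyl Arm of Compound 3

The source may hold more compounds than are shown below. What is called first, only, known or untested is meant among the compounds shown, and "the series" means these compounds.

Compound 1: `C=CCn1c(=O)n(CCCCO)c2nc(N)nc(O)c21`, 12%
Compound 2: `C=CCn1c(=O)n(Cc2ccccc2)c2nc(N)nc(O)c21`, 25%
Compound 3: `C=CCn1c(=O)n(CCCC)c2nc(N)nc(O)c21`, 77%

Of the compounds shown here, three sharing one core have been measured in a functional assay on the whole organism (B cells) with Mus musculus as the target; on this read-out lower numbers stand for smaller maximal responses and higher numbers for larger maximal responses. Compound 3 stands highest of the three: its nearest neighbour is compound 2, and the step of a number 52 percentage points higher from compound 2 to compound 3 (beyond the scatter) is beyond the scatter, as is the step of a number 65 percentage points higher from compound 1 to compound 3 (beyond the scatter) from the furthest compound. The smaller step of a number 13 percentage points higher from compound 1 to compound 2 (beyond the scatter) is also beyond the scatter. Both large steps end at compound 3, where the side chain bound to the aromatic nitrogen carries neither a hydroxy group nor a phenyl group.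

Compound 4, `C=CCn1c(=O)n(CCCCCCCC)c2nc(N)nc(O)c21`, is not yet measured. It differs from compound 3 by butyl in place of hydrogen on a saturated chain carbon, four bonds along the chain from an aromatic nitrogen. Among the compounds with values here, no measured step adds carbon to an otherwise unchanged chain, so the two large steps bear on it only indirectly: they show that removing hydroxy and replacing phenyl by propyl both raised the response, and compound 4 keeps the plain chain without either group. The account therefore expects the step of a number 3 percentage points higher from compound 3 to compound 4 (within the scatter) in this assay to stay within the scatter, in either direction. Compound 4 is estimated at 80%, with a range from 55% to 100%.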

Compound 4, largest response reached (reported as maximal response), in percent of the reference or control that the assay uses: 130%
Beside the measured number, compound 4's estimate is 50 percentage points below it; measured number outside the range, above it.
By their numbers in this assay, from the lowest: compound 1; then compound 2; then compound 3; then compound 4.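

In this assay, within the data shown here, adding carbon alone to the plain chain proves enough to move the read-out, since butyl in place of hydrogen on a saturated chain carbon, four bonds along the chain from an aromatic nitrogen, gives a number 53 percentage points higher from compound 3 to compound 4 (beyond the scatter) and no earlier step isolated chain length in this way. The two older contrasts also widen: butyl in place of hydroxy at that same place gives a number 118 percentage points higher from compound 1 to compound 4 (beyond the scatter) in this series, and the long plain chain set against the side chain that carries phenyl gives a number 105 percentage points higher from compound 2 to compound 4 (beyond the scatter) in this series, so compound 3 did not mark the top of the plain-chain series. Nothing at hand accounts for this rise with chain length.

On these data alone, whether a longer chain than that of compound 4 would raise the number further or lower it stays open, as does the shape of the rise across the chains of intermediate length. Also open, as far as these compounds go, is how an amine or a carboxylic acid at the end of the long chain would compare with the plain chain of compound 4.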